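This account rests on a few compounds, and the source may have more. Where it says the series, first, only, none or still open, it means among the compounds named here.

Working notes on the series. Three compounds on the shared core have been run in a functional assay on HCT-116 cells (Homo sapiens) for antiproliferative activity, read by MTT assay, with a stated time of 48 h; on this read-out lower numbers stand for stronger inhibition and higher numbers for weaker inhibition. Compound 1 `CS(=O)(=O)c1ccc(Nc2nccc(Nc3nc4ccc(F)cc4s3)n2)cc1` gives 860 nM. Compound 2 `COc1ccc2nc(Nc3nc(Nc4ccc(S(C)(=O)=O)cc4)ncc3F)sc2c1` gives 2630 nM. Compound 3 `COc1ccc2nc(Nc3ccnc(Nc4ccc(S(N)(=O)=O)cc4)n3)sc2c1` gives 1480 nM, which sits between the numbers of compound 1 and compound 2 but within the scatter of each, so no ranking among the three rests on it. Compound 4 `COc1ccc2nc(Nc3ccnc(Nc4ccc(S(C)(=O)=O)cc4)n3)sc2c1` is not yet measured; it differs from compound 3 by methyl in place of amino on a sulfonyl sulfur. For the measured compounds named here, no single-point step between measured compounds is available. Compound 1 and compound 2 already carry methylsulfonyl but differ from compound 3 elsewhere as well, so their numbers only bracket the region. The step from compound 3 to compound 4 is expected to be a 1.1-fold lower number from compound 3 to compound 4 (0.06 log units; within the scatter), nothing beyond the scatter in either direction. For compound 4 the estimate in this assay is 1300 nM, ranging from 500 nM to 3200 nM.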

Compound 4, half-maximal inhibitory concentration: 2270 nM
Compound 4: the middle estimate sits 1.7-fold (0.24 log units) below what was measured; the range from low to high includes it.
By their numbers in this assay, from the lowest: compounds 1, 3, 4 and 2 (each within the scatter of the next, the first and the last beyond it).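

In this assay, the change from sulfamoyl to methylsulfonyl, methyl in place of amino on a sulfonyl sulfur, stays within the scatter (a 1.5-fold higher number from compound 3 to compound 4 (0.19 log units; within the scatter)), as does hydrogen in place of fluoro on an aromatic carbon (a 1.2-fold lower number from compound 2 to compound 4 (0.06 log units; within the scatter)). Only methoxy in place of fluoro on an aromatic carbon gives a modest step beyond the scatter (a 2.6-fold higher number from compound 1 to compound 4 (0.42 log units; beyond the scatter)). No measurement on hand bears on the reason for any of these steps.

Open, on these data alone, is whether ethyl or dimethylamino on the sulfonyl sulfur, or a carboxylic acid in place of the whole sulfonyl group, would move the read-out beyond the scatter.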